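Series notes: trifluoromethyl in place of methoxy

The source may report more compounds than this note shows. Statements on the series, on what has been measured and on what is new or still open speak of the compounds shown alone.

Three measured compounds share one core and differ only in the group on the six-membered aromatic ring of carbon only. Compound 1 `CC1CC/C(=N\Nc2ccc(F)cc2)c2ncc(C(=O)O)c(=O)n21` gives 12.2 umol/kg in a functional assay on the whole organism for inhibition, with Rattus norvegicus as the target; a lower number here means that less compound is needed, a higher number that more compound is needed for the effect. Compound 2 `CC1CC/C(=N\Nc2ccc(Cl)cc2)c2ncc(C(=O)O)c(=O)n21` gives 0.5 umol/kg and compound 3 `COc1ccc(N/N=C2\CCC(C)n3c2ncc(C(=O)O)c3=O)cc1` gives 0.8 umol/kg. Compound 3 stands second highest of the three numbers; compound 2 is nearest and within the scatter of it, compound 1 is furthest and beyond the scatter. Two steps are large: a 24-fold lower number from compound 1 to compound 2 (1.39 log units; beyond the scatter) and a 15-fold lower number from compound 1 to compound 3 (1.18 log units; beyond the scatter). The third, a 1.6-fold higher number from compound 2 to compound 3 (0.20 log units; within the scatter), lies within the scatter.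

Compound 4 `CC1CC/C(=N\Nc2ccc(C(F)(F)F)cc2)c2ncc(C(=O)O)c(=O)n21` differs from compound 3 as follows: trifluoromethyl in place of methoxy on an aromatic carbon. Going by the values given here, no measured step involves trifluoromethyl, so the bearing of the measured steps is indirect: two different replacements of fluoro each gave a large lower number, and chloro against methoxy gave no step beyond the scatter. The expectation for compound 4 is therefore a step within the scatter, a 1.1-fold lower number from compound 3 to compound 4 (0.06 log units; within the scatter), in no clear direction. Compound 4 is estimated at 0.7 umol/kg, with a range from 0.2 umol/kg to 3 umol/kg.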

Compound 4, dose for 50% inhibition: 38.6 umol/kg
The estimate for compound 4 lay 55-fold (1.74 log units) below the measured number; measured number above the stated range.
By their numbers in this assay, from the lowest: compounds 2 and 3 (each within the scatter of the next); then compound 1; then compound 4.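

Trifluoromethyl in place of methoxy gives a 48-fold higher number from compound 3 to compound 4 (1.68 log units; beyond the scatter) and trifluoromethyl in place of chloro gives a 77-fold higher number from compound 2 to compound 4 (1.89 log units; beyond the scatter) so the low numbers of compound 2 and compound 3 in this assay do not extend to every group at this position. Trifluoromethyl in place of fluoro gives a 3.2-fold higher number from compound 1 to compound 4 (0.50 log units; beyond the scatter) which is a smaller step than the other two but still beyond the scatter, and trifluoromethyl now replaces fluoro as the group with the highest number. Going by these compounds alone, no measurement on these compounds offers an account of this split.

Open is where an amine, a nitrile or a carboxylic acid at this position would fall among these four groups. Also open, from the compounds shown here alone, is whether a methyl group or a longer chain would stand with chloro and methoxy or with fluoro and trifluoromethyl.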